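Thiourea series: chloro for methoxy on the amino-bearing ring

The source may hold more compounds than are shown below. What is called first, only, known or untested is meant among the compounds shown, and "the series" means these compounds.

Compound 2 `COc1ccc(NC(=S)NC(=O)c2cn(-c3ccccc3)nc2-c2ccc(OC)cc2)cc1`, compound 1 `O=C(NC(=S)Nc1ccc(F)cc1)c1cn(-c2ccccc2)nc1-c1ccc(F)cc1` and compound 3 `O=C(NC(=S)Nc1ccc(F)cc1)c1cn(-c2ccccc2)nc1-c1ccccc1` share one core and differ only in their aromatic substituents. In a functional assay on NCI-H460 cells (Homo sapiens) for inhibition, read by CCK-8 assay, with a stated time of 48 h (on this read-out lower numbers stand for stronger inhibition and higher numbers for weaker inhibition), compound 2 gives 2570 nM, compound 1 gives 3240 nM and compound 3 gives 4210 nM. Compound 2 has the lowest of the three numbers, yet its gaps to compound 1 and to compound 3 both lie within the scatter, so no order among the three can be read. Within the data shown here, the only single-point step available, a 1.3-fold higher number from compound 1 to compound 3 (0.11 log units; within the scatter), concerns a different aromatic carbon and is itself within the scatter. Compound 4 `COc1ccc(-c2nn(-c3ccccc3)cc2C(=O)NC(=S)Nc2ccc(Cl)cc2)cc1`, not yet measured, differs from compound 2 in one place: chloro in place of methoxy on an aromatic carbon. Among the measured compounds shown here, no measured pair isolates this change on the (4-methoxyphenyl)amino group; compound 1 and compound 2, which carry fluoro and methoxy at the corresponding positions, sit within the scatter of each other, and every variation seen so far has left this assay essentially flat. Hence no step beyond the scatter is expected for a 1.1-fold higher number from compound 2 to compound 4 (0.04 log units; within the scatter), in either direction. Compound 4 is therefore estimated at 2800 nM in this assay, with a range of 1300 nM to 6000 nM.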

Compound 4, half-maximal inhibitory concentration: 3010 nM
Compound 4: middle estimate off by 1.1-fold (0.03 log units), on the low side, within the range that was stated.
By their numbers in this assay, from the lowest: compounds 2, 4, 1 and 3 (each within the scatter of the next).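

In this assay the exchange of methoxy for chloro gives a 1.2-fold higher number from compound 2 to compound 4 (0.07 log units; within the scatter), so a single-point pair now isolates this change on the ring that carries the amino group. Among the earlier compounds, this position changed only together with a second substituent, whereas here the step from (4-methoxyphenyl)amino to (4-chlorophenyl)amino stands alone and does not leave the scatter. No measurement shown here offers an explanation for this result.

The compounds shown leave open whether any group at this position can move the number beyond the scatter, since only fluoro, methoxy and chloro appear there. Among these compounds, an amine, a carboxylic acid or a longer chain such as butoxy on this aromatic carbon would test that, in a series where no step read so far exceeds the scatter.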